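A few compounds are considered here, and "the series" means these few. Any claim that something is new, unique, unknown or untested is made for them only; others in the source may bear on it.

Compound 1 `COC(=O)c1sc2cc(C#Cc3ccc(N)cc3)cnc2c1N` is the reference point of this short series. For the measured compounds named here, in a functional assay on A375-C5 cells (Homo sapiens) for inhibition, read by sulforhodamine B assay, with a stated time of 48 h (on this read-out lower numbers stand for stronger inhibition of growth and higher numbers for weaker inhibition of growth), compound 1 gives 4800 nM, the lower of the two numbers measured so far. Going by the values given here, its only measured neighbour is compound 2 `COC(=O)c1sc2cc(C#Cc3ccc(N(C)C)cc3)cnc2c1N`, which in this assay gives 17700 nM; the step of a 3.7-fold higher number from compound 1 to compound 2 (0.57 log units; beyond the scatter) shows that enlarging the amino group on the aromatic carbon weakens growth inhibition by a modest but real margin. Compound 3 `COC(=O)c1sc2cc(C#Cc3cccc(OC)c3)cnc2c1N` has not been measured. The change from compound 1 is 3-methoxyphenyl in place of 4-aminophenyl on a triple-bonded carbon. Among the compounds with values here, no measured step covers this exact change: the step to compound 2 altered the amino group but kept it, whereas here the donor is removed and a methoxy group on a different ring position enters. Within the data shown here, that step is the only guide, and it points to a weakening of similar modest size, so a step of a 3.1-fold higher number from compound 1 to compound 3 (0.49 log units; beyond the scatter) is expected. Compound 3 is therefore estimated at 15000 nM, with a plausible range from 5000 nM to 45000 nM.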

Compound 3, concentration for 50% growth inhibition: > 75000 nM
Compound 3: no number, only a limit; the forecaster's own chance of this, stated with the estimate: 10%; at least 5.0-fold (0.69 log units) between middle value and limit.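

In this assay compound 3 gives > 75000 nM, which is a limit of the assay and not a number. Replacing the group on the triple-bonded carbon brings an at least 15-fold higher number from compound 1 to compound 3 (1.19 log units; beyond the scatter), so this place responds far more strongly to the exchange of 4-aminophenyl for 3-methoxyphenyl than to the change on the nitrogen seen in a 3.7-fold higher number from compound 1 to compound 2 (0.57 log units; beyond the scatter). Among these three compounds, a measurable number stays only where a nitrogen group remains on the ring, so the place is not indifferent to what the aromatic ring carries.

The step combines the loss of the amino group, the arrival of methoxy and a different ring position, and these three cannot be separated here. Compounds carrying 4-methoxyphenyl, 3-aminophenyl or plain phenyl on the triple-bonded carbon would be needed to tell which of them accounts for the loss.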